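Chain-lengthened amide series: cytotoxicity in HEL cells

A few compounds are considered here, and "the series" means these few. Any claim that something is new, unique, unknown or untested is made for them only; others in the source may bear on it.

Working notes on a small set of amides sharing one core. Compound 1 (`CCCCCCNc1cncc(C(=O)NCc2ccccc2)n1`) was tested in an ADME assay on HEL cells (Homo sapiens) for cytotoxicity, read by microscopy, with a stated time of 6 days; a lower number here means that less compound is tolerated, a higher number that more compound is tolerated. Its result is a limit of the assay rather than a number: compound 1 gives > 100000 nM. This is the case described by the limit of > 100000 nM in this assay, at which 1 of the 3 values shown sits, so compound 1 stands at the edge of what the assay can report and its true tolerated concentration is not pinned down. Compound 2 (`CCCCCCCNc1nccnc1C(=O)NCc1ccccc1`), a regioisomer with the chain on a different ring position, gives 100000 nM in this assay, and this is a measured number. Compound 3 (`O=C(NCc1ccccc1)c1cnc(Cl)cn1`) carries a chlorine in place of the alkylamino chain; for compound 3 the entry in this assay reads "not determined" (no result reported), so it contributes nothing to the numbers.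

Compound 4 (`CCCCCCCNc1cncc(C(=O)NCc2ccccc2)n1`) has not yet been run in this assay. It differs from compound 1 by methyl in place of hydrogen on a saturated chain carbon, six bonds along the chain from a nitrogen on an aromatic ring. Among the measured compounds shown here, no step between two measured compounds is available for this kind of change. With compound 1 at the limit > 100000 nM and compound 2 at a matching value, the expected step of a number no higher from compound 1 to compound 4 (the limit leaves the size open) is none beyond the scatter. Compound 4 is therefore expected to give 100000 nM, with a range from 50000 nM to 200000 nM, and a real chance that only a limit is returned.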

Compound 4, minimum cytotoxic concentration: > 100000 nM
Compound 4 ended at the assay's limit; the forecaster's own chance of this, stated with the estimate: 60%; the middle value lies on the limit itself.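

Compound 1 and compound 4 both end at the limit of this assay and no value is reported past it, so no step between these two compounds can be read: the limit of > 100000 nM in this assay, at which 2 of the 4 values shown sit.

The compounds shown leave open how far past that limit either compound lies, and whether methyl in place of hydrogen on the chain changes the tolerated concentration at all.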